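Methoxy for fluoro on an N-methyl trimethoxyphenyl benzamide

The source may report more compounds than this note shows. Statements on the series, on what has been measured and on what is new or still open speak of the compounds shown alone.

Compound 2 `COc1cc(N(C)C(=O)c2ccc(F)cc2)cc(OC)c1OC` is tested in a functional assay on ONS-76 cells (Homo sapiens) for cytotoxicity, read by MTT assay, with a stated time of 72 h; a lower number here means a stronger inhibitor, a higher number a weaker inhibitor. In this assay compound 2 reaches only the limit of >= 125000 nM, which is a boundary of the assay and not a number. Compound 1 `COc1cc(N(C)C(=O)c2cccc(F)c2)cc(OC)c1OC` likewise reaches only the limit of >= 125000 nM in this assay. Compound 3 `COc1cc(NC(=O)c2ccc3ccccc3c2)cc(OC)c1OC` gives 26800 nM in this assay. The one step among these compounds, a step that the two limits leave unreadable from compound 1 to compound 2, cannot be read as a size, since the limit of >= 125000 nM in this assay, at which 2 of the 3 values shown sit, covers both ends. Compound 4 `COc1ccc(C(=O)N(C)c2cc(OC)c(OC)c(OC)c2)cc1` differs from compound 2 by methoxy in place of fluoro on an aromatic carbon, on an aromatic carbon of a six-membered aromatic ring of carbon only, para to a large group; cut one bond further out it reads as 4-fluorophenyl to 4-methoxyphenyl. For the measured compounds named here, no measured step bears directly on this change, and the two N-methylated compounds, compound 1 and compound 2, both sit at the limit. Compound 4 is therefore expected to stay near that limit, with a step of a number no higher from compound 2 to compound 4 (the limit leaves the size open) of no readable size, and its estimate is 125000 nM with a range from 40000 nM to 300000 nM.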

Compound 4, half-maximal inhibitory concentration: >= 125000 nM
Compound 4 gave a limit, no number; the forecaster's own chance of this, stated with the estimate: 70%; the middle value lies on the limit itself.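

Compound 4 also stops at a limit of the assay, >= 125000 nM, so its steps from compound 1 and compound 2 cannot be read: the limit of >= 125000 nM in this assay, at which 3 of the 4 values shown sit.

The compounds shown leave open whether compound 1, compound 2 and compound 4 differ at all in this assay, and so whether methoxy or fluoro on that aromatic carbon matters.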